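Ethoxy to propoxy on a weak growth inhibitor

This account rests on a few compounds, and the source may have more. Where it says the series, first, only, none or still open, it means among the compounds named here.

In a functional assay on HepG2 cells (Homo sapiens) for antiproliferative activity, read by MTT assay, with a stated time of 48 h (a lower number here means a stronger inhibitor of growth, a higher number a weaker inhibitor of growth), compound 3 `CCOC(=O)N1N=C(c2ccc(OC)cc2)CC1c1cc(OC)c(OC)c(OC)c1` gives 9400 nM, the higher of the two true numbers available, which makes it the weaker inhibitor of that pair. The other number comes from compound 2 `COC(=O)N1N=C(c2ccc(OC)cc2)CC1c1cc(OC)c(OC)c(OC)c1`, which gives 1710 nM. Compound 1 `CCCOC(=O)N1N=C(c2cccc(OC)c2)CC1c1cc(OC)c(OC)c(OC)c1` gives only > 10000 nM, which is a limit of the assay and not a number.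

Compound 4 `CCCOC(=O)N1N=C(c2ccc(OC)cc2)CC1c1cc(OC)c(OC)c(OC)c1` differs from compound 3 by one small change, ethoxy to propoxy: methyl takes the place of hydrogen on a saturated chain carbon, two bonds along the chain from an oxygen next to a carbonyl group (methyl in place of hydrogen on a saturated chain carbon, two bonds along the chain from an oxygen next to a carbonyl group).

Going by the values given here, one measured step bears on this. Methyl in place of hydrogen on the saturated chain carbon bound to that oxygen gave a 5.5-fold higher number from compound 2 to compound 3 (0.74 log units; beyond the scatter). Among the compounds with values here, that change sits at a different carbon of the chain, and it is the only such step measured, so it suggests a direction more firmly than a size. A weaker result in this assay is therefore expected, though by less than that step, and the assay may report only a limit. The expected change is a 1.5-fold higher number from compound 3 to compound 4 (0.17 log units; within the scatter). For compound 4 the estimated value is 14000 nM, with an expected range from 5000 nM to 40000 nM.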

Compound 4, concentration for 50% growth inhibition: > 10000 nM
Compound 4: no number, only a limit; the forecaster's own chance of this, stated with the estimate: 60%; the middle value is on the limit's open side.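

At the saturated chain carbon two bonds along the chain from an oxygen next to a carbonyl group, the step reads as an at least 1.0-fold higher number from compound 3 to compound 4 (0.02 log units; that floor lies within the scatter), so this result alone does not establish that propoxy is weaker than ethoxy. The comparison with the shortest chain is clearer, with an at least 5.8-fold higher number from compound 2 to compound 4 (0.76 log units; beyond the scatter), so in this assay both lengthenings shown, methoxy to ethoxy and methoxy to propoxy, give a higher number, and none of the compounds that differ only in this chain goes against that. The step from compound 1 to compound 4, which would compare 3-methoxyphenyl with 4-methoxyphenyl on the propoxy series, cannot be read, because both compounds sit at a limit: the limit of > 10000 nM in this assay, at which 2 of the 4 values shown sit.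

Going by these compounds, it remains open how far compound 4 lies past its limit, and so how large the change from ethoxy to propoxy really is. On these data alone, it is also open whether a different group on the carbonyl, such as an amine in place of the alkoxy chain or a longer chain ending in a carboxylic acid, would bring growth inhibition back towards that of compound 2.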